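A few compounds are considered here, and "the series" means these few. Any claim that something is new, unique, unknown or untested is made for them only; others in the source may bear on it.

Measured so far in a functional assay on HCT-116 cells (Homo sapiens) for inhibition, read by sulforhodamine B assay, with a stated time of 48 h, tested at 50 uM; a higher number here means more inhibition of growth at the concentration tested, a lower number less inhibition of growth:

- compound 1, `COc1cc(/C=C/C(=O)/C=C/c2cc(OC)c(OC)c(OC)c2)ccc1OCc1cn(CCCCCOc2cc(=O)oc3ccccc23)nn1`, 53%
- compound 2, `COc1cc(/C=C/C(=O)/C=C/c2cccc3ccccc23)ccc1OCc1cn(CCCCOc2cc(=O)oc3ccccc23)nn1`, 56%
- compound 3, `COc1ccc(/C=C/C(=O)/C=C/c2ccc(OCc3cn(CCOc4cc(=O)oc5ccccc45)nn3)c(OC)c2)cc1`, 71%

Among these three numbers compound 2 stands second highest. Its nearest neighbour is compound 1, whose growth inhibition lies a little lower but within the usual scatter of this assay, so the two cannot be told apart. The furthest is compound 3, whose number is higher by a margin beyond the scatter.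

Compound 4, `COc1cccc(/C=C/C(=O)/C=C/c2ccc(OCc3cn(CCCCOc4cc(=O)oc5ccccc45)nn3)c(OC)c2)c1`, has not yet been measured. It differs from compound 2 in one place: 3-methoxyphenyl in place of naphthalen-1-yl on a double-bonded chain carbon bound to a double-bonded chain carbon. Among the measured compounds shown here, no pair of measured compounds differs by exactly this change, so there is no measured step to lean on. For the measured compounds named here, the only hint is that compound 3, which also carries a methoxyphenyl group on the chain, gives 71% in this assay, the highest of the three. A small upward step is therefore expected, perhaps not beyond the scatter.

Compound 4 is estimated at 60% in this assay, within a range from 45% to 75%. This expectation corresponds to a step of a number 4 percentage points higher from compound 2 to compound 4 (within the scatter).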

Compound 4, percent growth inhibition at one concentration: 44%
Beside the measured number, compound 4's estimate is 16 percentage points above it; measured number outside the range, below it.
By their numbers in this assay, from the lowest: compounds 4, 1 and 2 (each within the scatter of the next, the first and the last beyond it); then compound 3.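

In this assay, among the compounds shown here, this is the first measured step at this position: putting 3-methoxyphenyl in place of naphthalen-1-yl on a double-bonded chain carbon bound to a double-bonded chain carbon gives a number 12 percentage points lower from compound 2 to compound 4 (beyond the scatter) with the rest of the molecule unchanged. The group at this place therefore does affect growth inhibition, and in this one pair the naphthalen-1-yl with its two aromatic rings carries the higher number. No measurement shown gives a reason for this difference.

The compounds shown leave open whether the methoxy group or the loss of a ring accounts for the step, a question that an unsubstituted phenyl at this place could help answer. They also leave open whether the step would hold with a longer chain leading to the triazole.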